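The source may hold more compounds than are shown below. What is called first, only, known or untested is meant among the compounds shown, and "the series" means these compounds.

Compound 1 `COc1ncnc2c1c(I)cn2[C@@H]1O[C@H](CO)[C@@H](O)[C@H]1O`: > 20000 nM
Compound 2 `CN(C)c1ncnc2c1c(-c1cc3ccccc3o1)cn2[C@@H]1O[C@H](CO)[C@@H](O)[C@H]1O`: > 20000 nM

All values come from a functional assay on A549 cells (Homo sapiens), read by MTT assay, with a stated time of 72 h; a lower number here means a stronger inhibitor, a higher number a weaker inhibitor. For compound 1 the result is a limit of the assay rather than a number: in this assay compound 1 gives > 20000 nM. The same holds for compound 2, which in this assay gives > 20000 nM, again only a limit. Among the measured compounds shown here, compound 1 therefore stands at the limit of > 20000 nM in this assay, at which 2 of the 2 values shown sit, and no step between measured compounds can be drawn from the two results.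

Compound 3 `COc1ncnc2c1c(-c1ccco1)cn2[C@@H]1O[C@H](CO)[C@@H](O)[C@H]1O` is not yet measured. It differs from compound 1 in one place: furan-2-yl in place of iodo on an aromatic carbon. For the measured compounds named here, with no measured step to rest on, the change is expected to bring no shift beyond the scatter, and compound 3 is most likely to reach only the limit again. The step is estimated as a step that the limit leaves unreadable from compound 1 to compound 3. Compound 3 is expected to give 25000 nM in this assay, within a range of 8000 nM to 80000 nM.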

Compound 3, half-maximal inhibitory concentration: 30 nM
Compound 3: the middle estimate sits 830-fold (2.92 log units) above what was measured; measured number outside the range, below it.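

In this assay, furan-2-yl in place of iodo on this aromatic carbon gives an at least 660-fold lower number from compound 1 to compound 3 (2.82 log units; beyond the scatter). The earlier results offered no number to work from, whereas this pair shows that the group on this one carbon can, with the rest of the molecule unchanged, separate a compound held at an assay limit from one with a real reading. Even so, the picture rests on very few numbers: the limit of > 20000 nM in this assay, at which 2 of the 3 values shown sit.

From the compounds shown here alone, whether the gain needs the furan oxygen or only an aromatic ring stays open, and a phenyl or thiophen-2-yl group on the same carbon would help to tell these apart. The role of the methoxy group is also unsettled, and an amine in its place, with furan-2-yl kept, would address that question.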